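Cytotoxicity in HepG2 cells: from compound 2 to compound 4

The compounds below may be only part of what the source reports. "The series", "measured", "known", "first", "only" and "open" are said of these compounds alone.

Measured so far in an ADME assay on HepG2 cells (Homo sapiens) for cytotoxicity, read by trypan blue exclusion, with a stated time of 48 h, in the presence of a further agent that is not named here; on this read-out lower numbers stand for higher toxicity in this test and higher numbers for lower toxicity in this test:
compound 1 `c1ccc(Cn2cnc3c(-c4ccco4)nccc32)cc1` — > 25000 nM
compound 2 `COc1ccc2nc(C)cc(OCC(=O)Nc3ccc(Br)cc3)c2c1` — > 125000 nM
compound 3 `COc1ccc2nc(C)cc(OCC(=O)Nc3ccc(-c4ccccc4)cc3)c2c1` — > 126000 nM

None of these is a number. The value of compound 1 is a limit of the assay. The value of compound 2 is likewise a limit of the assay. The value of compound 3 is also a limit of the assay. Compound 2 therefore stands only at a limit, and the two other values shown are limits as well, so no order among the three can be read.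

Among the compounds with values here, the one step between measured compounds, a step that the two limits leave unreadable from compound 2 to compound 3, cannot be sized, because the limit of > 125000 nM in this assay, at which 1 of the 3 values shown sits, and the limit of > 126000 nM in this assay, at which 1 of the 3 values shown sits, both cap the read-out. The account now turns to compound 4 `COCCNC(=O)COc1cc(C)nc2ccc(OC)cc12`, which is not yet measured. Its difference from compound 2 is 2-methoxyethyl in place of 4-bromophenyl on an amide-type nitrogen, a change on an amide-type nitrogen whose other neighbour is a carbonyl carbon.

No measured step bears on this change with a readable size; the only step shown is unreadable. The expectation therefore rests on compound 2 alone, whose value is a limit, and it is expected that compound 4 again reaches a limit, with the step of a number no higher from compound 2 to compound 4 (the limit leaves the size open) expected to fall within the scatter. Compound 4 is estimated at 125000 nM, in the range 50000 nM to 300000 nM.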

Compound 4, half-maximal cytotoxic concentration: > 164000 nM
Compound 4: only a limit was reported; the forecaster's own chance of this, stated with the estimate: 85%; at least 1.3-fold (0.11 log units) between middle value and limit.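

In this assay compound 4 gives > 164000 nM, which is a limit of the assay. Compound 2 also stands only at a limit, so the step from compound 2 to compound 4 cannot be read. The compounds shown leave open whether 2-methoxyethyl in place of 4-bromophenyl on an amide-type nitrogen changes the half-maximal cytotoxic concentration at all.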